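A longer chain after a step within the scatter

The compounds below may be only part of what the source reports. "The series", "measured", "known", "first", "only" and "open" are said of these compounds alone.

compound 1 `O=C(CCCN=C=S)Nc1ccc2ncnc(Nc3cccc(Br)c3)c2c1`: 16300 nM
compound 2 `O=C(CCCCCN=C=S)Nc1ccc2ncnc(Nc3cccc(Br)c3)c2c1`: 16500 nM
compound 3 `O=C(CCCCCCN=C=S)Nc1ccc2ncnc(Nc3cccc(Br)c3)c2c1`: not yet measured

For the measured compounds named here, in a functional assay on HaCaT cells (Homo sapiens) for inhibition, read by MTT assay, with a stated time of 72 h (on this read-out higher numbers stand for weaker inhibition and lower numbers for stronger inhibition), compound 2 gives 16500 nM, which lies within the scatter of compound 1, the only other compound measured so far. The structural change that leads on to compound 3 is a group of 4 heavy atoms (2 carbon, 1 nitrogen, 1 sulfur; no ring) in place of a group of 3 heavy atoms (1 carbon, 1 nitrogen, 1 sulfur; no ring), on a saturated chain carbon, five bonds along the chain from a carbonyl carbon. Going by the values given here, one measured step bears on this change, and it is a similar replacement on a saturated chain carbon: a 1.0-fold higher number from compound 1 to compound 2 (0.01 log units; within the scatter). Among the compounds with values here, that step stayed within the scatter, and no measured step in this assay goes beyond it. A single step is thin evidence, but it gives no reason to expect a real shift in either direction, so none beyond the scatter is expected here. The expected step is a 1.0-fold lower number from compound 2 to compound 3 (0.01 log units; within the scatter). Compound 3 is estimated at 16000 nM, with an expected range from 8500 nM to 30000 nM.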

Compound 3, half-maximal inhibitory concentration: 17300 nM
The estimate for compound 3 lay 1.1-fold (0.03 log units) below the measured number, within the range that was stated.
By their numbers in this assay, from the lowest: compounds 1, 2 and 3 (each within the scatter of the next).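

In this assay, the group of 4 heavy atoms (2 carbon, 1 nitrogen, 1 sulfur) in place of the group of 3 heavy atoms (1 carbon, 1 nitrogen, 1 sulfur), on a saturated chain carbon, five bonds along the chain from a carbonyl carbon, gives a 1.0-fold higher number from compound 2 to compound 3 (0.02 log units; within the scatter). Where the earlier compounds offered a single step, the widest span of chain lengths shown now also stays within the scatter, with a 1.1-fold higher number from compound 1 to compound 3 (0.03 log units; within the scatter), so all three chains give numbers that cannot be told apart in this read-out. No supporting data are available to account for this result.

From the compounds shown here alone, whether a much longer chain would also leave the number unmoved remains open. So does the outcome of placing an amine or a carboxylic acid in place of the sulfur-bearing group, since all three compounds carry that same group.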